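A few compounds are considered here, and "the series" means these few. Any claim that something is new, unique, unknown or untested is made for them only; others in the source may bear on it.

Working notes on the series. The shared core carries a methoxy group, an amide to a substituted hydroxypiperidine and a chlorobenzylamino group on the fused ring, as in compound 1 `COc1cc(C(=O)N2CC(C)C(O)CC2C)cc2nc(NCc3cccc(Cl)c3)oc12`. In an assay on isolated protein for inhibition of thyroid hormone receptor beta (Homo sapiens), read by fluorescence, with a stated time of 30 min (on this read-out higher numbers stand for weaker inhibition and lower numbers for stronger inhibition), compound 1 gives 66 nM; 45 nM (2 entries), and these repeat entries of compound 1 the several entries of compound 1 in this assay, 66 nM; 45 nM (2 entries) set the working spread of the read-out. Among the measured compounds shown here, compound 2 `CCC1CC(O)C(C)CN1C(=O)c1cc(OC)c2oc(NCc3cccc(Cl)c3)nc2c1` carries an ethyl group on the saturated ring in place of a methyl group and sits differently on the piperidine; in this assay compound 2 gives 13 nM, which is the only number for compound 2 here, a further entry having yielded no single figure. Compound 3 `COc1cc(C(=O)N2CC(C)C(O)CC2C2CC2)cc2nc(NCc3cccc(Cl)c3)oc12` is not yet measured. It differs from compound 2 only in cyclopropyl in place of ethyl on a saturated ring carbon. For the measured compounds named here, no measured pair in the set isolates such a change, so the step from compound 2 to compound 3 is expected to stay within the usual scatter, with no direction claimed, as a 1.2-fold higher number from compound 2 to compound 3 (0.06 log units; within the scatter) states. On that basis compound 3 is estimated at 15 nM in this assay, with a range from 5 nM to 45 nM.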

Compound 3, half-maximal inhibitory concentration: 8 nM
Estimate against measurement, compound 3: 1.9-fold (0.27 log units) above; measured number inside the range.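

Cyclopropyl in place of ethyl, on the saturated ring carbon next to the ring nitrogen and next to the ring atom that bears a large group, gives in this assay a 1.6-fold lower number from compound 2 to compound 3 (0.21 log units; within the scatter). Among the compounds shown here, this is the first step that isolates a single change at this position, and it shows that the read-out does not separate the two groups here: a three-membered ring of carbon can stand on this carbon in place of the open ethyl chain without a change beyond the scatter. The repeat entries of compound 1 provide the measure of spread against which this step is read: the several entries of compound 1 in this assay, 66 nM; 45 nM (2 entries)

The compounds shown carry only small groups made of carbon at this position, so it remains open how the read-out responds to a longer chain such as n-butyl, to a phenyl ring, or to a group that brings in other atoms, such as an amine or a carboxylic acid. As far as these compounds go, it also remains open whether this step would hold with a group other than the hydroxy and methyl groups on the same ring, since both stay unchanged across compound 2 and compound 3.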